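Nitro in Place of Fluoro: A Second Example

The source may report more compounds than this note shows. Statements on the series, on what has been measured and on what is new or still open speak of the compounds shown alone.

Compound 1 `CC1=C(/C=C/C(=O)/C=C/c2cccc(F)c2)C(C)(C)CCC1O` and compound 2 `CC1=C(/C=C/C(=O)/C=C/c2ccc(F)cc2)C(C)(C)CCC1O` are built on the same core and differ only in the change (4-fluorophenyl in place of 3-fluorophenyl on a double-bonded chain carbon bound to a double-bonded chain carbon). In a functional assay on LNCaP cells (Homo sapiens) for cytotoxicity, read by MTT assay, with a stated time of 72 h (on this read-out lower numbers stand for stronger inhibition and higher numbers for weaker inhibition), compound 1 gives 4400 nM, while compound 2 gives 3900 nM, and the step of a 1.1-fold lower number from compound 1 to compound 2 (0.05 log units; within the scatter) separates them. Compound 3 `CC1=C(/C=C/C(=O)/C=C/c2cccc([N+](=O)[O-])c2)C(C)(C)CCC1O` arises from compound 1 through the change (nitro in place of fluoro on an aromatic carbon); in this assay compound 3 gives 2000 nM, so that a 2.2-fold lower number from compound 1 to compound 3 (0.34 log units; beyond the scatter). Compound 4 `CC1=C(/C=C/C(=O)/C=C/c2ccc([N+](=O)[O-])cc2)C(C)(C)CCC1O`, not yet measured, arises from compound 2 through the change (nitro in place of fluoro on an aromatic carbon). The two changes are of the same kind but not the same: in compound 3 the nitro sits meta to a large group, in compound 4 para to a large group. Because compound 1 and compound 2 lie within the scatter of each other by a 1.1-fold lower number from compound 1 to compound 2 (0.05 log units; within the scatter), the step for compound 4 is expected to resemble the earlier one, with a 2.1-fold lower number from compound 2 to compound 4 (0.31 log units; beyond the scatter). This expectation rests on the measured step of a 2.2-fold lower number from compound 1 to compound 3 (0.34 log units; beyond the scatter). Compound 4 is therefore estimated at 1900 nM, with a likely range from 900 nM to 4000 nM.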

Compound 4, half-maximal inhibitory concentration: 4200 nM
The estimate for compound 4 lay 2.2-fold (0.34 log units) below the measured number, and the stated range ends below it.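

In this assay, nitro in place of fluoro on the core of compound 2 gave a 1.1-fold higher number from compound 2 to compound 4 (0.03 log units; within the scatter), so this step stays within the scatter, whereas the same change on the core of compound 1 went beyond it. Even so, the two steps cannot be told apart, and the contrast between them does not establish that the place of the nitro on the ring decides the outcome: the same change on two cores in this assay, a 2.2-fold lower number (0.34 log units; beyond the scatter) from compound 1 to compound 3 and a 1.1-fold higher number (0.03 log units; within the scatter) from compound 2 to compound 4, 2.4-fold (0.37 log units) apart, within the scatter of two such steps The result therefore shows neither that this change carries over from one core to the other nor that it fails to, since each core offers only a single pair.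

The compounds shown leave open whether a different group on the same aromatic carbon, such as an amine or a carboxylic acid, would give steps that match on the two cores. They also leave open whether a further pair would separate the two steps more clearly than this one does.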